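The source may report more compounds than this note shows. Statements on the series, on what has been measured and on what is new or still open speak of the compounds shown alone.

Values measured in a physicochemical assay for lipophilicity (on this read-out lower numbers stand for lower lipophilicity and higher numbers for higher lipophilicity), are these:

- compound 1 `COC(=O)/C=C\C(=O)c1ccccc1` with 1.49
- compound 2 `C/C(=C/C(=O)O)C(=O)c1ccccc1` with 1.69

Among the compounds with values here, compound 1 stands within the usual scatter of compound 2, the only other compound measured, so these two numbers do not rank them in this assay as a pair.

Compound 3 `COC(=O)/C=C/C(=O)c1ccccc1` has not yet been measured. Set against compound 1, it shows the two compounds have the same atoms and bonds and differ only in configuration as drawn: 1 of 1 stereo elements differ; a double bond is drawn Z in compound 1 and E in compound 3 and nothing else: a double bond is drawn Z in compound 1 and E in compound 3. Within the data shown here, no measured pair shows a change of this kind, so the data offer no direct guide to its size. A small rise that stays inside the scatter is expected, and the estimated move is a number 0.16 log units higher from compound 1 to compound 3 (within the scatter) on this read-out. The estimate for compound 3 is 1.65 with an expected range from 1.35 to 1.95 in this assay.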

Compound 3, partition coefficient: 2.24
Compound 3: middle estimate off by 0.59 log units, on the low side; measured number above the stated range.
By their numbers in this assay, from the lowest: compounds 1 and 2 (each within the scatter of the next); then compound 3.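

Turning the double bond from Z to E gives, in this assay, a number 0.75 log units higher from compound 1 to compound 3 (beyond the scatter), the only step in the set so far. Within the data shown here, this shows that the drawn configuration of this one double bond can, on its own, move the number in this assay beyond the scatter, something compounds 1 and 2 could not show, as they form no single-change pair. The step can be tied to this double bond alone because nothing else separates the two structures: the fact that compounds 1 and 3 differ only in the configuration as drawn

On these data alone, this is a single pair, so it remains open whether the same switch would give a step of similar size and direction elsewhere. A primary amide or an ethyl ester in place of the methyl ester could test this, as could a halogen on the phenyl ring.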